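Cyclopentyl on the imidazole amine: expected cytotoxicity on Vero cells

The source may hold more compounds than are shown below. What is called first, only, known or untested is meant among the compounds shown, and "the series" means these compounds.

The account concerns a pair of close relatives built on one shared core. Compound 1 `Nc1nc(-c2c(-c3ccc(F)cc3)nn3c(NC4CCCC4)cccc23)c[nH]1` carries a free amino group on its imidazole, while compound 2 `Fc1ccc(-c2nn3c(NC4CCCC4)cccc3c2-c2ccnc(NC3CCCC3)n2)cc1` carries the cyclopentylamino group on a pyrimidine instead. In an ADME assay on Vero cells (Chlorocebus sabaeus) for cytotoxicity (on this read-out lower numbers stand for higher toxicity in this test and higher numbers for lower toxicity in this test), compound 1 is recorded as "not determined" (no result reported), so it stands without a number of its own. In this assay compound 2 reaches only a limit of the test, > 160000 nM, and this is the single figure shown: the limit of > 160000 nM in this assay, at which 1 of the 2 values shown sits. Compound 3 `Fc1ccc(-c2nn3c(NC4CCCC4)cccc3c2-c2c[nH]c(NC3CCCC3)n2)cc1` has not yet been tested in this assay. It differs from compound 1 by the change (cyclopentyl in place of hydrogen on a nitrogen on an aromatic ring), that is, the free amino group becomes the cyclopentylamino group on the imidazole ring. Going by the values given here, no measured step between two compounds is available, so no size can be drawn from the data. Among the compounds with values here, the only anchor is compound 2, whose limit in this assay suggests weak cytotoxicity for this core with a cyclopentylamino substituent. Compound 3 is therefore expected to sit around 160000 nM in this assay, within a range of roughly 40000 nM to 400000 nM, and it may well return only a limit again.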

Compound 3, half-maximal cytotoxic concentration: 40000 nM
Compound 3: the middle estimate sits 4.0-fold (0.60 log units) above what was measured; the measured number falls inside the stated range.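

No new step can be read from this result: compound 1 has no number of its own in this assay, so compound 3, at 40000 nM, cannot be paired with it. The compounds shown leave open how far the change from amino to cyclopentylamino on the imidazole shifts the half-maximal cytotoxic concentration in this assay.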